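The compounds below may be only part of what the source reports. "The series", "measured", "known", "first", "only" and "open" are said of these compounds alone.

Working notes on the series. Among the compounds with values here, in a functional assay on MOLT-4 cells (Homo sapiens) for antiproliferative activity, read by CCK-8 assay, with a stated time of 72 h (a lower number here means a stronger inhibitor, a higher number a weaker inhibitor), compound 1 (`Cc1cc(Nc2cc(N3CCN(C)CC3)nc(Nc3ccc(S(N)(=O)=O)cc3)n2)n[nH]1`) gives 648 nM, the highest of the two numbers measured so far. Within the data shown here, the only comparison available is compound 2 (`Cc1cc(Nc2cc(N3CCN(C)CC3)nc(Nc3ccc([N+](=O)[O-])cc3)n2)n[nH]1`), which gives 18.1 nM. Compound 3 (`Cc1cc(Nc2cc(N3CCN(C)CC3)nc(Nc3ccc(Cl)cc3)n2)n[nH]1`) has not yet been measured. It departs from compound 1 by chloro in place of sulfamoyl on an aromatic carbon, para to a large group.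

Among the measured compounds shown here, one measured step bears on this change. Nitro in place of sulfamoyl gives a 36-fold lower number from compound 1 to compound 2 (1.55 log units; beyond the scatter), a large step beyond the scatter. For the measured compounds named here, compound 3 loses the same sulfamoyl group, but it gains chloro rather than nitro, and no measured compound yet carries chloro. The nitro step can therefore guide the direction, while its size transfers only loosely. A large step towards a lower number is expected in this assay, probably somewhat smaller than the nitro step. The expected change is a 14-fold lower number from compound 1 to compound 3 (1.16 log units; beyond the scatter). For compound 3 the estimated value is 45 nM, with an expected range from 12 nM to 170 nM.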

Compound 3, half-maximal inhibitory concentration: 53.1 nM
Estimate against measurement, compound 3: 1.2-fold (0.07 log units) below; measured number inside the range.
By their numbers in this assay, from the lowest: compound 2; then compound 3; then compound 1.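

The fall in the number on leaving sulfamoyl is not confined to nitro: in this assay, chloro at the same aromatic carbon gives a 12-fold lower number from compound 1 to compound 3 (1.09 log units; beyond the scatter), so two different replacements now lie well below the sulfamoyl compound. The entering group still matters, since chloro in place of nitro gives a 2.9-fold higher number from compound 2 to compound 3 (0.47 log units; beyond the scatter), a modest step that is nevertheless beyond the scatter, which puts the 4-nitrophenyl compound lowest of the three and separates it from the 4-chlorophenyl compound. Nothing available accounts for this order.

On these data alone, it remains open whether an amine, a carboxylic acid or a methoxy group at this carbon would fall with chloro and nitro or stay near sulfamoyl, and three compounds cannot show which feature of the group governs the number. Also open, as far as these compounds go, is whether the same order of these three groups would hold if another part of the shared core were changed, since all three compounds differ in this one place only.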